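The compounds below may be only part of what the source reports. "The series", "measured", "known", "first", "only" and "open" are said of these compounds alone.

In a functional assay on MCF-10A cells (Homo sapiens) for antiproliferative activity, with a stated time of 48 h (a lower number here means that less compound is needed, a higher number that more compound is needed for the effect), compound 1 (`COc1ccc2nc(C)cc(NCc3ccc(C)cc3)c2c1`) gives 18800 nM and compound 2 (`COc1ccc2nc(C)cc(NCc3cccc(F)c3)c2c1`) gives 11300 nM while compound 3 (`COc1ccc2nc(C)cc(NCc3cccc(OC(F)F)c3)c2c1`) gives 10300 nM on the same core. The number for compound 2 lies between the other two, within the scatter of both. Compound 4 (`COc1ccc2nc(C)cc(NCc3ccc(OC)c(F)c3)c2c1`) differs from compound 2 by a single change (methoxy in place of hydrogen on an aromatic carbon): methoxy in place of hydrogen on an aromatic carbon. Among the compounds with values here, two measured steps bear on it: a 1.7-fold lower number from compound 1 to compound 2 (0.22 log units; within the scatter) and a 1.1-fold lower number from compound 2 to compound 3 (0.04 log units; within the scatter) for exchanges of other groups. Neither goes beyond the scatter, so no step beyond the scatter is expected in this assay for compound 4 either. The estimate means a 1.0-fold lower number from compound 2 to compound 4 (0.01 log units; within the scatter) as the expected step. Compound 4 is estimated at 11000 nM (expected range 5500 nM to 22000 nM).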

Compound 4, half-maximal effective concentration: 9000 nM
For compound 4 the middle estimate is 1.2-fold (0.09 log units) above the measured one; low and high end bracket the measured number.
By their numbers in this assay, from the lowest: compounds 4, 3, 2 and 1 (each within the scatter of the next, the first and the last beyond it).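

With methoxy in place of hydrogen on an aromatic carbon, ortho to a fluoro group and para to a large group, a substituent is added to compound 2 rather than exchanged for another. In this assay the result is a 1.3-fold lower number from compound 2 to compound 4 (0.10 log units; within the scatter) and shows that this added methoxy is tolerated at this position without a change beyond the scatter. No measurement available here explains this result.

Going by these compounds, whether an amine or a carboxylic acid at this place would shift the number beyond the scatter remains open. So does whether methoxy would behave alike without the fluoro group.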